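This account rests on a few compounds, and the source may have more. Where it says the series, first, only, none or still open, it means among the compounds named here.

Compound 2 `CCCCOC(=O)NS(=O)(=O)c1sc(CC(C)C)cc1-c1ccc(CN2C(=O)CCC2=O)cc1` carries the (2,5-dioxopyrrolidin-1-yl)methyl group on an aromatic carbon of a six-membered aromatic ring of carbon only. In an assay on membranes from uterus for displacement of a labelled ligand from Angiotensin type II receptor (Sus scrofa), with a stated time of 1.5 h (on this read-out higher numbers stand for weaker inhibition and lower numbers for stronger inhibition), compound 2 gives only > 10000 nM, which is a limit of the assay and not a number (the limit of > 10000 nM in this assay, at which 1 of the 2 values shown sits). Compound 1 `CCCCOC(=O)NS(=O)(=O)c1sc(CC(C)C)cc1-c1ccc(C(=O)c2ncco2)cc1`, with (1,3-oxazol-2-yl)carbonyl on that aromatic carbon instead, gives 13.8 nM in this assay. Among the measured compounds shown here, the step of an at least 720-fold higher number from compound 1 to compound 2 (2.86 log units; beyond the scatter) is the only measured step, and it bears directly on the next change. Compound 3 `CCCCOC(=O)NS(=O)(=O)c1sc(CC(C)C)cc1-c1ccc(C(=O)c2nccs2)cc1` differs from compound 2 by (1,3-thiazol-2-yl)carbonyl in place of (2,5-dioxopyrrolidin-1-yl)methyl on an aromatic carbon. This change restores a carbonyl-linked five-membered aromatic ring of the kind whose loss, from compound 1 to compound 2, raised the number far beyond the scatter; a large drop in this assay is therefore expected, of roughly the size of the measured step but in the opposite direction. Compound 3 is expected at 20 nM (range 6 nM to 80 nM), an expected step of an at least 500-fold lower number from compound 2 to compound 3 (2.69 log units; beyond the scatter).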

Compound 3, inhibition constant: 18.6 nM
Beside the measured number, compound 3's estimate is 1.1-fold (0.03 log units) above it, within the range that was stated.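

In this assay, 1,3-thiazol-2-yl in place of 1,3-oxazol-2-yl on the carbonyl carbon gives a 1.3-fold higher number from compound 1 to compound 3 (0.13 log units; within the scatter), so this read-out does not separate the two aromatic rings. Replacing (2,5-dioxopyrrolidin-1-yl)methyl with (1,3-thiazol-2-yl)carbonyl at this place, para to a large group, gives an at least 530-fold lower number from compound 2 to compound 3 (2.73 log units; beyond the scatter), so a second carbonyl-linked five-membered aromatic ring stands far from compound 2. This step has a bound on one side only, as the value of compound 2 is a limit of the assay and not a number: the limit of > 10000 nM in this assay, at which 1 of the 3 values shown sits.

On these data alone, the linker and the ring differ together between compound 2 and the other two compounds, so it stays open which of them carries the large steps. A methylene linker to 1,3-thiazol-2-yl, or a benzoyl group in place of the five-membered ring, would separate the two.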